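Swapping one aryl group on a shared core against a dichlorophenyl

A few compounds are considered here, and "the series" means these few. Any claim that something is new, unique, unknown or untested is made for them only; others in the source may bear on it.

Of the compounds shown here, three have been tested in a functional assay on Huh-7 cells (Homo sapiens) for cytotoxicity, read by CCK-8 assay, with a stated time of 72 h; a higher number here means a weaker inhibitor, a lower number a stronger inhibitor. Compound 1 `C=CCn1c(=O)/c(=C\c2cc(F)ccc2C)[nH]c(=O)/c1=C\c1ccccc1OC` gives 5600 nM, the highest number of the three and therefore the weakest inhibitor among them. Compound 2 `COc1ccccc1/C=c1\c(=O)[nH]/c(=C/c2ccccc2Cl)c(=O)n1C` gives 300 nM in this assay, and compound 3 `COc1ccccc1/C=c1/[nH]c(=O)/c(=C\c2nc[nH]c2C(C)(C)C)[nH]c1=O` gives 90 nM, both well beyond the scatter from compound 1. Each of these compounds differs from compound 1 in more than one place, so no single structural step between measured compounds can be isolated.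

Compound 4 `C=CCn1c(=O)/c(=C\c2ccc(Cl)c(Cl)c2)[nH]c(=O)/c1=C\c1ccccc1OC` is not yet measured. It differs from compound 1 in one place: 3,4-dichlorophenyl in place of 5-fluoro-2-methylphenyl on a double-bonded chain carbon bound to an aromatic carbon.

Among the compounds with values here, the data offer no direct precedent for this exchange. With the other two compounds carrying quite different groups at that position and both showing lower numbers, a modest improvement is plausible, though a step within the scatter cannot be excluded. The step of a 2.2-fold lower number from compound 1 to compound 4 (0.35 log units; beyond the scatter) is the expected size. Compound 4 is estimated at 2500 nM in this assay, with a range from 600 nM to 10000 nM.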

Compound 4, half-maximal inhibitory concentration: "not active" (no number reported)
Nothing numeric was reported for compound 4, so the estimate cannot be set against anything.
By their numbers in this assay, from the lowest: compound 3; then compound 2; then compound 1.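

In this assay, within the data shown here, compound 4 is reported only as "not active", without a number, so no step from compound 1 can be read. Nothing shown explains this result. The compounds shown leave open how large the effect of exchanging 5-fluoro-2-methylphenyl for 3,4-dichlorophenyl is.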